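From 4-ethylphenyl to 3,5-dimethylphenyl on sulfur

The source may hold more compounds than are shown below. What is called first, only, known or untested is meant among the compounds shown, and "the series" means these compounds.

In a functional assay on HeLa cells (Homo sapiens) for inhibition, read by CCK-8 assay, with a stated time of 72 h, tested at 2 uM (a lower number here means less inhibition of growth, a higher number more inhibition of growth at the concentration tested), compound 1 (`CCc1ccc(SCc2ccc(C(=O)Nc3ccccc3N)cc2)cc1`) gives 30.8%, the second highest of the three numbers available. Compound 2 (`Nc1ccccc1NC(=O)c1ccc(CSc2nccc(C(F)(F)F)n2)cc1`) stands higher at 68.3% and compound 3 (`Nc1ccccc1NC(=O)c1ccc(CSc2ccc(C(F)(F)F)cn2)cc1`) lower at 11.5%, both gaps from compound 1 being beyond the scatter. Compound 4 (`Cc1cc(C)cc(SCc2ccc(C(=O)Nc3ccccc3N)cc2)c1`) carries 3,5-dimethylphenyl in place of 4-ethylphenyl on a sulfur. Going by the values given here, no measured pair shows a step of this kind, so the expectation rests on compound 1 at 30.8%. No step beyond the scatter is expected in this assay, and no firm direction. The estimated step is a number 1.8 percentage points lower from compound 1 to compound 4 (within the scatter). For compound 4 the estimated value is 29%, with an expected range of 10% to 52%.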

Compound 4, percent growth inhibition at one concentration: 40.2%
The estimate for compound 4 lay 11.2 percentage points below the measured number, and the stated range covers the measured number.
By their numbers in this assay, from the lowest: compound 3; then compounds 1 and 4 (each within the scatter of the next); then compound 2.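

In this assay, the first step read at this position is 3,5-dimethylphenyl in place of 4-ethylphenyl on a sulfur, with a number 9.4 percentage points higher from compound 1 to compound 4 (within the scatter). With the same atoms in both groups, rearranging the carbons on this aromatic ring therefore does not separate the two compounds in this read-out. No available evidence bears on the reason for this result.

Going by these compounds, whether a 4-aminophenyl group or a longer chain such as 4-butylphenyl on the same sulfur would give a step beyond the scatter stays open. Going by these compounds alone, also open is how these carbon-only aromatic rings relate to compound 2 and compound 3, since no single-place step connects them.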